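Moving the methoxy group on the alkyne-linked phenyl ring

The source may hold more compounds than are shown below. What is called first, only, known or untested is meant among the compounds shown, and "the series" means these compounds.

Compound 1 `COC(=O)c1sc2cc(C#Cc3ccc(OC)cc3)cnc2c1N` is the point of departure. In a functional assay on NCI-H460 cells (Homo sapiens) for inhibition, read by sulforhodamine B assay, with a stated time of 48 h (a lower number here means a stronger inhibitor of growth, a higher number a weaker inhibitor of growth), compound 1 gives 320 nM, the lowest of the three numbers at hand. Compound 2 `COC(=O)c1sc2cc(C#Cc3ccccc3N)cnc2c1N` gives 5700 nM, and compound 3 `COC(=O)c1sc2cc(C#Cc3cccc(N)c3)cnc2c1N` gives 11500 nM; the step of an 18-fold higher number from compound 1 to compound 2 (1.25 log units; beyond the scatter) and the step of a 36-fold higher number from compound 1 to compound 3 (1.56 log units; beyond the scatter) are both large, while the step of a 2.0-fold higher number from compound 2 to compound 3 (0.30 log units; within the scatter) stays within the scatter, so these two aminophenyl variants cannot be told apart.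

Compound 4 `COC(=O)c1sc2cc(C#Cc3cccc(OC)c3)cnc2c1N` keeps every atom of compound 1 and differs only by the change (3-methoxyphenyl in place of 4-methoxyphenyl on a triple-bonded carbon). The measured steps bear on it indirectly: they show that replacing 4-methoxyphenyl with an aminophenyl weakens growth inhibition strongly, but none of them isolates a pure move of the methoxy group, and the near-equal values of compound 2 and compound 3 suggest the position of a small substituent may matter less than its identity. A moderate rise in the number is therefore expected, a 3.1-fold higher number from compound 1 to compound 4 (0.49 log units; beyond the scatter), with wide uncertainty. Compound 4 is estimated at 1000 nM, within 300 nM to 4000 nM.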

Compound 4, concentration for 50% growth inhibition: 49000 nM
Compound 4: the middle estimate sits 49-fold (1.69 log units) below what was measured, outside the stated range (above it).
By their numbers in this assay, from the lowest: compound 1; then compounds 2 and 3 (each within the scatter of the next); then compound 4.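

Moving the methoxy group, with the same atoms joined differently, gives in this assay a 150-fold higher number from compound 1 to compound 4 (2.19 log units; beyond the scatter) and so shows that the place of this group on the ring matters greatly, which compounds 2 and 3, within the scatter of each other, did not reveal. At the same ring place, methoxy in place of amino gives a 4.3-fold higher number from compound 3 to compound 4 (0.63 log units; beyond the scatter) and thus a further loss, while the change from 2-aminophenyl gives an 8.6-fold higher number from compound 2 to compound 4 (0.93 log units; beyond the scatter) as well. Compound 4 is therefore the weakest of the four, and a methoxy group alone does not secure the low number of compound 1. Nothing available explains these differences.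

Going by these compounds, how a 4-aminophenyl group or a 2-methoxyphenyl group would compare on this triple-bonded carbon stays open. So does whether the 4-position favours other groups too.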